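The source may hold more compounds than are shown below. What is called first, only, known or untested is meant among the compounds shown, and "the series" means these compounds.

Measured so far in a functional assay on MDA-MB-231 cells (Homo sapiens) for inhibition, read by sulforhodamine B assay, tested at 10 uM; on this read-out higher numbers stand for more inhibition at the one concentration tested (going by the name of the read-out) and lower numbers for less inhibition:
compound 1, `CN1CCN(c2ccc(C3=NNC(c4ccc(N(C)C)cc4)C3)cc2)CC1`, gives 11.4%
compound 2, `CN1CCN(c2ccc(C3=NN(C(=O)CCCl)C(c4ccc(N(C)C)cc4)C3)cc2)CC1`, gives 2.4%
compound 3, `CN(C)c1ccc(C2CC(c3ccc(-n4cncn4)cc3)=NN2C(=O)CCCl)cc1`, gives 3.7%

Compound 3 holds the second highest of the three numbers in this assay. Its nearest neighbour is compound 2, the gap being a number 1.3 percentage points higher from compound 2 to compound 3 (within the scatter); the gap to compound 1 is also within the scatter, so the three measured numbers cannot be ranked against one another.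

Compound 4 is `Cc1ccc(S(=O)(=O)N2N=C(c3ccc(-n4cncn4)cc3)CC2c2ccc(N(C)C)cc2)cc1`. It differs from compound 3 in one place: (4-methylphenyl)sulfonyl in place of (2-chloroethyl)carbonyl on an amine nitrogen in a ring.

Among the compounds with values here, only one measured step touches the same position, the amine nitrogen in the five-membered ring: a number 9 percentage points lower from compound 1 to compound 2 (within the scatter). The other step, a number 1.3 percentage points higher from compound 2 to compound 3 (within the scatter), concerns an aromatic carbon and is less directly comparable, but it too stayed within the scatter. Within the data shown here, no measured compound carries a (4-methylphenyl)sulfonyl group, so nothing in the data speaks to that group itself. Among the measured compounds shown here, both acylated ring nitrogens seen so far sit at low inhibition, and no step in the set has moved beyond the scatter.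

For compound 4 the expected step is therefore a number 1.3 percentage points higher from compound 3 to compound 4 (within the scatter), in no direction beyond the scatter. Compound 4 is estimated at 5%, within a range from -6% to 16%.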

Compound 4, a percentage reported as inhibition, at one concentration (the size of the read-out at that concentration, not a potency): 20.7%
Compound 4: middle estimate off by 15.7 percentage points, on the low side; the measured number lies above the stated range.
By their numbers in this assay, from the lowest: compounds 2, 3, 1 and 4 (each within the scatter of the next, the first and the last beyond it).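

In this assay, the amine nitrogen in the ring is shown to be a position where a change of substituent can move the read-out: a number 17 percentage points higher from compound 3 to compound 4 (beyond the scatter), the first step in the series to pass the scatter. The change replaces (2-chloroethyl)carbonyl, with 5 heavy atoms and no ring, by (4-methylphenyl)sulfonyl, with 10 heavy atoms and one six-membered aromatic ring of carbon only, so the swap alters the linking group and the attached fragment in a single step. No measurement available here explains the step or assigns it to any one part of the entering group.

The compounds shown leave open whether the sulfonyl link, the aromatic ring or its methyl group carries the step; a methylsulfonyl group and a benzoyl group on the same nitrogen would separate the link from the ring, and a phenylsulfonyl group would isolate the methyl. Also open, as far as these compounds go, is whether the step holds with 4-methylpiperazin-1-yl in place of 1H-1,2,4-triazol-1-yl, and whether a larger or more strongly substituted arylsulfonyl group, such as naphthylsulfonyl, extends it further.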